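Butyl for butanamide on the exocyclic nitrogen

The compounds below may be only part of what the source reports. "The series", "measured", "known", "first", "only" and "open" are said of these compounds alone.

Compound 1 `Nc1ncc(-c2ccccc2)c(-c2ccccc2)n1` gives 32% in an assay on CHO cells for displacement of a labelled ligand from adenosine receptor A1 (Homo sapiens), read by scintillation counting, with a stated time of 1 h, tested at 1 uM; a higher number here means more inhibition at the concentration tested (going by the name of the read-out), a lower number less inhibition. Compound 2 `CCCC(=O)Nc1ncc(-c2cccc(Cl)c2)c(-c2ccccc2)n1` carries a chlorophenyl and an acylated amino group. In this assay, as far as these compounds go, compound 2 reaches only the limit of the assay, > 80%, so its true number is unknown (the limit of > 80% in this assay, at which 1 of the 2 values shown sits). Compound 3 `CCCCNc1ncc(-c2cccc(Cl)c2)c(-c2ccccc2)n1` is not yet measured; it differs from compound 2 by butyl in place of propylcarbonyl on a nitrogen on an aromatic ring. Going by the values given here, no measured step covers such a change, so the expectation for compound 3 rests on compound 1 and compound 2 alone. The step of a number at least 25 percentage points lower from compound 2 to compound 3 (beyond the scatter) is expected to be a loss beyond the scatter, but compound 3 is still expected to sit above compound 1. For compound 3 an inhibition of 55% is estimated, with a range from 25% to 85%.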

Compound 3, a percentage reported as inhibition, at one concentration (the size of the read-out at that concentration, not a potency): 56%
Compound 3: middle estimate off by 1 percentage points, on the low side, within the range that was stated.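

In this assay, the place on a nitrogen on an aromatic ring responds to the nature of its substituent: butyl in place of propylcarbonyl gives a number at least 24 percentage points lower from compound 2 to compound 3 (beyond the scatter). The chlorophenyl and the rest of the core stay the same across this pair, so the drop belongs to this single change. Compound 2 stands at a limit, so the full size of the step stays unknown: the limit of > 80% in this assay, at which 1 of the 3 values shown sits.

The compounds shown leave open whether the carbonyl or the chain length matters more. Acetyl, a longer acyl chain or the free amine on the same nitrogen, with the chlorophenyl kept, would bear on this.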